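Shortening the Amine Chain on a Flavone Ether

A few compounds are considered here, and "the series" means these few. Any claim that something is new, unique, unknown or untested is made for them only; others in the source may bear on it.

The series shares one core, carried in compound 1 `COc1cc(OC)c2c(=O)cc(-c3ccc(OCCF)cc3)oc2c1`, and varies only the ether on the pendant ring. In a functional assay (Homo sapiens) for antiproliferative activity, read by resazurin assay, with a stated time of 48 h, tested at 5 uM (a lower number here means a weaker effect, a higher number a stronger effect of the compound at the concentration tested), compound 1 gives "not active" (no number reported). Compound 3 `COc1cc(OC)c2c(=O)cc(-c3ccc(OC4CCNCC4)cc3)oc2c1` likewise gives "not active" (no number reported) in this assay. For the measured compounds named here, compound 2 `COc1cc(OC)c2c(=O)cc(-c3ccc(OCCCN(C)C)cc3)oc2c1` is the one member with a number: in this assay compound 2 gives 36%, so it stands alone as the only measured effect among the three, with the other two entries carrying no figure at all.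

Compound 4 `COc1cc(OC)c2c(=O)cc(-c3ccc(OCCN)cc3)oc2c1` is the next step from compound 2. The change is amino in place of (dimethylamino)methyl on a saturated chain carbon, two bonds along the chain from an oxygen on an aromatic ring.

Going by the values given here, no step between two measured compounds is available to calibrate this change, so the direction can only be read from the pattern that compound 1 and compound 3 give no effect while compound 2 does. The chain that ends in the amine of compound 2 is the only one tied to a measured number, and the shorter chain with the bare amine of compound 4 is expected to fall back toward the inactive entries rather than gain.

The step from compound 2 to compound 4 is therefore expected to be a number 18 percentage points lower from compound 2 to compound 4 (beyond the scatter), a loss beyond the usual scatter. Compound 4 is estimated at 18% in this assay, within a range of 0% to 36%, with a fair chance that no number is reported.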

Compound 4, a percentage reported as inhibition, at one concentration (the size of the read-out at that concentration, not a potency): 6%
Estimate against measurement, compound 4: 12 percentage points above; the range from low to high includes it.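

In this assay, for the compounds shown here, replacing 3-(dimethylamino)propoxy with 2-aminoethoxy gives a number 30 percentage points lower from compound 2 to compound 4 (beyond the scatter) and so provides the first measured step for this ether on the pendant ring. The result shows that the read-out responds to this change and that a chain ending in an amine does not by itself preserve the effect of compound 2, as compound 4 gives 6% despite carrying its own terminal amine. No measurement at hand accounts for the loss, and the step stands here as an observation only.

Going by these compounds alone, the single step shortens the chain and removes the two methyl groups from the nitrogen together, so the share of each in the loss remains unresolved. Comparing 2-(dimethylamino)ethoxy, which has the shorter chain with the dimethylamino end kept, and 3-aminopropoxy, which has the longer chain with the bare amine, against compound 2 and compound 4 would separate the two changes, while 4-(dimethylamino)butoxy would show whether a still longer chain continues the trend.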